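The compounds below may be only part of what the source reports. "The series", "measured", "known", "first", "only" and "open" are said of these compounds alone.

Measured so far in an ADME assay on BaF3 cells (Mus musculus) for cytotoxicity, read by MTT assay, with a stated time of 48 h; a higher number here means a weaker inhibitor of growth, a lower number a stronger inhibitor of growth:
compound 1 `CC(C)n1nc(-c2cc(-c3ccccc3)on2)c2c(N)ncnc21`
compound 2 `CC(C)n1nc(-c2cc(C3CCCCC3)on2)c2c(N)ncnc21`
compound 3 `CC(C)c1cc(-c2nn(C(C)C)c3ncnc(N)c23)no1`

In this assay compound 1 gives > 10000 nM, a limit of the assay. Compound 2 gives > 10000 nM in this assay, also a limit. Compound 3 gives > 10000 nM in this assay, a limit as well; it stands at the limit of > 10000 nM in this assay, at which 3 of the 3 values shown sit, so no number is known for it. Compound 4 `CC(C)n1nc(-c2ccon2)c2c(N)ncnc21` differs from compound 3 by hydrogen in place of isopropyl on an aromatic carbon. The steps at this aromatic carbon, a step that the two limits leave unreadable from compound 1 to compound 3 and a step that the two limits leave unreadable from compound 2 to compound 3, and likewise a step that the two limits leave unreadable from compound 1 to compound 2, cannot be read; all three values sit at the limit. None gives a size for the change to compound 4. The step from compound 3 to compound 4 is therefore expected to be a step that the limit leaves unreadable from compound 3 to compound 4, most likely leaving compound 4 at the limit again. Compound 4 is expected to give 12000 nM in this assay, ranging from 3000 nM to 40000 nM.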

Compound 4, concentration for 50% growth inhibition: > 10000 nM
Compound 4 was reported as a limit; the forecaster's own chance of this, stated with the estimate: 85%; the middle value does not contradict the limit.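

Compound 4 is also a limit, so no step among compound 1, compound 2, compound 3 and compound 4 can be read: the limit of > 10000 nM in this assay, at which 4 of the 4 values shown sit.

The compounds shown leave open whether any group at this aromatic carbon gives a readable number in this assay.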